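This account rests on a few compounds, and the source may have more. Where it says the series, first, only, none or still open, it means among the compounds named here.

Measured in a functional assay on the whole organism (strain Sprague-Dawley) for inhibition, with Rattus norvegicus as the target, with a stated time of 10 min; a higher number here means that more compound is needed for the effect, a lower number that less compound is needed:
- compound 1 `CCOc1ccc(OC)cc1-c1ncc(C(=O)O)c(=O)[nH]1` gives 0.2 mg/kg
- compound 2 `CCCOc1ccc(OC)cc1-c1ncc(C(=O)O)c(=O)[nH]1` gives 0.3 mg/kg

The two measured compounds stand level, because a 1.5-fold higher number from compound 1 to compound 2 (0.18 log units; within the scatter) does not exceed the scatter, so compound 2 has no real separation from compound 1. Compound 3 `CCCOc1ccc(OC)cc1-c1ncc(C(=O)OCC)c(=O)[nH]1` differs from compound 2 in one place, (ethyl in place of hydrogen on an oxygen next to a carbonyl group), which turns carboxy into ethoxycarbonyl. Within the data shown here, the only measured step lies on the saturated chain, not at the carboxy, so it says nothing directly about this change and no measured step covers it. Starting from compound 2 at 0.3 mg/kg in this assay, a moderately higher number is expected, though with little support and a wide margin. The expected size is a 3.3-fold higher number from compound 2 to compound 3 (0.52 log units; beyond the scatter) and it remains an estimate. Compound 3 is estimated at 1 mg/kg, with an expected range from 0.2 mg/kg to 5 mg/kg.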

Compound 3, dose for 50% inhibition: 0.7 mg/kg
For compound 3 the middle estimate is 1.4-fold (0.15 log units) above the measured one, and the stated range covers the measured number.
By their numbers in this assay, from the lowest: compounds 1 and 2 (each within the scatter of the next); then compound 3.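

The earlier step lay on the saturated chain, so this is the first reading at the carboxy group: in this assay the change from carboxy to ethoxycarbonyl brings a 2.3-fold higher number from compound 2 to compound 3 (0.37 log units; beyond the scatter) and is the only step shown so far that goes beyond the scatter. More compound is therefore needed once ethyl replaces hydrogen on this oxygen next to a carbonyl group, but the step is modest and compound 3 still gives 0.7 mg/kg in this assay with no free carboxy hydrogen. Nothing at hand gives a reason for this rise.

As far as these compounds go, whether a methyl ester or a primary amide in this place would stand nearer to compound 2 or to compound 3 remains open. From the compounds shown here alone, it is equally open whether the same change on compound 1 gives a step of like size, and what a butyl chain on the aromatic oxygen would give.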